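The source may report more compounds than this note shows. Statements on the series, on what has been measured and on what is new or still open speak of the compounds shown alone.

Measured in a functional assay on MT4 cells (Homo sapiens) for cytotoxicity; on this read-out lower numbers stand for higher toxicity in this test and higher numbers for lower toxicity in this test:
- compound 1 `CC(C)c1c(O)nc(SCC(=O)c2ccc(F)cc2)nc1Cc1cccc2ccccc12`: 186000 nM
- compound 2 `CCOC(=O)CSc1nc(O)c(C(C)C)c(Cc2cccc3ccccc23)n1`: 175000 nM

Among the measured compounds shown here, compound 2 stands within the scatter of compound 1, the only other measured compound, so neither can be ranked. The next compound is compound 3 `Cc1ccc(C(=O)CSc2nc(O)c(C(C)C)c(Cc3cccc4ccccc34)n2)c(C)c1`, with the change (2,4-dimethylphenyl in place of ethoxy on a carbonyl carbon). For the measured compounds named here, the one measured step bearing on this is a 1.1-fold lower number from compound 1 to compound 2 (0.03 log units; within the scatter), where ethoxy took the place of 4-fluorophenyl on a carbonyl carbon. With an aryl group swapped for ethoxy at the same place and no shift beyond the scatter there, none is expected here in this assay. The expected change is a 1.1-fold lower number from compound 2 to compound 3 (0.03 log units; within the scatter). Compound 3 is estimated at 165000 nM, with an expected range of 70000 nM to 350000 nM.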

Compound 3, half-maximal cytotoxic concentration: 27000 nM
Compound 3: middle estimate off by 6.1-fold (0.79 log units), on the high side; measured number below the stated range.
By their numbers in this assay, from the lowest: compound 3; then compounds 2 and 1 (each within the scatter of the next).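

In this assay the group on the carbonyl carbon can shift the read-out beyond the scatter: 2,4-dimethylphenyl gives a 6.5-fold lower number from compound 2 to compound 3 (0.81 log units; beyond the scatter) when it replaces ethoxy and a 6.9-fold lower number from compound 1 to compound 3 (0.84 log units; beyond the scatter) when it replaces 4-fluorophenyl. An aromatic ring at this place does not by itself go with a lower number, as compound 1 carries one and goes against that reading. No measurement at hand explains the shift.

Still open, going by these compounds, is whether 2-methylphenyl or 4-methylphenyl alone would match 2,4-dimethylphenyl. Also open, on these data alone, is how an aminophenyl group would read at this place.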